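The source may report more compounds than this note shows. Statements on the series, on what has been measured and on what is new or still open speak of the compounds shown alone.

Measured compounds:
Compound 1 `Cn1cnc2c1c(=O)n(CC(=O)O)c(=O)n2C` — 0.8%
Compound 2 `Cn1cnc2c1c(=O)n(CC(=O)N1CCSCC1)c(=O)n2C` — 5.6%

In a functional assay on MGC-803 cells (Homo sapiens) for inhibition, read by MTT assay, with a stated time of 48 h, tested at 20 uM (on this read-out lower numbers stand for less inhibition and higher numbers for more inhibition at the one concentration tested (going by the name of the read-out)), compound 1 gives 0.8% and compound 2 gives 5.6%. Of the two numbers shown, compound 2 carries the larger one, but the step of a number 4.8 percentage points higher from compound 1 to compound 2 (within the scatter) lies within the scatter, so the two compounds cannot be told apart on this read-out.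

Compound 3 `Cn1cnc2c1c(=O)n(CC(=O)N1CCC(F)(F)CC1)c(=O)n2C` differs from compound 2 by 4,4-difluoropiperidin-1-yl in place of thiomorpholin-4-yl on a carbonyl carbon. Going by the values given here, the only measured step, a number 4.8 percentage points higher from compound 1 to compound 2 (within the scatter), concerns the same carbonyl carbon, yet it exchanged a hydroxy group for a ring rather than one ring for another, and it stayed within the scatter. It therefore bears only loosely on the present change and gives no ground to expect a step beyond the scatter in this assay in either direction; the expected step is a number 0.4 percentage points higher from compound 2 to compound 3 (within the scatter). Compound 3 is estimated at 6%, with a range from -4% to 18%.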

Compound 3, a percentage reported as inhibition, at one concentration (the size of the read-out at that concentration, not a potency): 11.3%
For compound 3 the middle estimate is 5.3 percentage points below the measured one; the range from low to high includes it.
By their numbers in this assay, from the lowest: compounds 1, 2 and 3 (each within the scatter of the next, the first and the last beyond it).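

In this assay, exchanging one ring for another on the carbonyl carbon gives a number 5.7 percentage points higher from compound 2 to compound 3 (within the scatter), so thiomorpholin-4-yl and 4,4-difluoropiperidin-1-yl cannot be told apart at this position. Going by these compounds alone, measured against the hydroxy group, however, 4,4-difluoropiperidin-1-yl gives a number 10.5 percentage points higher from compound 1 to compound 3 (beyond the scatter), the first step at this position to clear the scatter, though only modestly, which the step to thiomorpholin-4-yl did not do. Nothing available explains this result.

The compounds shown leave open whether the ring itself matters, or whether an open-chain diethylamide or a piperazine amide on the same carbonyl carbon would read alike. They also leave open whether any other group at this position would give a step well beyond the scatter.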